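Changing the group on the carbonyl carbon of compound 3

The compounds below may be only part of what the source reports. "The series", "measured", "known", "first", "only" and "open" are said of these compounds alone.

Of the compounds shown here, three sharing one core have been measured in an assay on isolated protein for inhibition of aldehyde dehydrogenase 1A1 (Homo sapiens), read by spectrophotometry, tested at 10 uM; a higher number here means more inhibition at the concentration tested (going by the name of the read-out), a lower number less inhibition. Compound 1 `Cc1cccc(Cn2c(CN3CCN(C(=O)c4ccncc4)CC3)nc3ccccc32)c1` gives 20.6%, compound 2 `Cc1cccc(Cn2c(CN3CCN(C(=O)C4CCCCC4)CC3)nc3ccccc32)c1` gives 31.9%, and compound 3 `Cc1cccc(Cn2c(CN3CCN(C(=O)c4cccs4)CC3)nc3ccccc32)c1` gives 60.8%. Compound 3 stands highest of the three: its nearest neighbour is compound 2 and compound 1 lies furthest from it, each gap beyond the scatter. The steps that reach compound 3 are a number 40.2 percentage points higher from compound 1 to compound 3 (beyond the scatter) and a number 28.9 percentage points higher from compound 2 to compound 3 (beyond the scatter); the remaining step, a number 11.3 percentage points higher from compound 1 to compound 2 (beyond the scatter), shows how much cyclohexyl alone gains over pyridin-4-yl.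

Compound 4 `Cc1ccc(C(=O)N2CCN(Cc3nc4ccccc4n3Cc3cccc(C)c3)CC2)cc1` differs from compound 3 in one place: 4-methylphenyl in place of thiophen-2-yl on a carbonyl carbon. Both steps into compound 3 bear on this change, since each of them put thiophen-2-yl in place of another group and both were beyond the scatter; nothing measured shows 4-methylphenyl itself. Read backwards, the two steps say that taking thiophen-2-yl away has so far cost inhibition, though neither earlier exchange set one aromatic ring against another as this one does. A downward step of modest size is therefore expected, a number 20.8 percentage points lower from compound 3 to compound 4 (beyond the scatter). Compound 4 is estimated at 40%, with a range from 20% to 62%.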

Compound 4, a percentage reported as inhibition, at one concentration (the size of the read-out at that concentration, not a potency): 64.9%
Beside the measured number, compound 4's estimate is 24.9 percentage points below it, and the stated range ends below it.
By their numbers in this assay, from the lowest: compound 1; then compound 2; then compounds 3 and 4 (each within the scatter of the next).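

In this assay, within the data shown here, the change from thiophen-2-yl to 4-methylphenyl on a carbonyl carbon gives a number 4.1 percentage points higher from compound 3 to compound 4 (within the scatter) and so sets one aromatic ring against another for the first time, showing that a six-membered aromatic ring of carbon only can stand in for the five-membered ring with its sulfur without a change that can be told from the scatter. The same group also gives a number 33 percentage points higher from compound 2 to compound 4 (beyond the scatter) and a number 44.3 percentage points higher from compound 1 to compound 4 (beyond the scatter) so the high level of inhibition at this position does not belong to thiophen-2-yl alone, although compound 1 goes against any reading that an aromatic ring here is enough, as its pyridin-4-yl stays low. Nothing among the data accounts for these differences.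

The compounds shown leave open whether the methyl group of compound 4 matters at all, as plain phenyl does not appear among them, and whether a chlorine, a methoxy group or an amine could take the place of that methyl. They also leave open how a thiophene carrying a methyl group, or a longer chain between the carbonyl carbon and the ring, would read in this assay on the shared core.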